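Bicyclic heteroaryl exchange on the chain carbon: compound 4

The source may hold more compounds than are shown below. What is called first, only, known or untested is meant among the compounds shown, and "the series" means these compounds.

compound 1 `O=C1O/C(=C\Cn2cnc3c(F)nc(F)c(Cl)c32)C(OCc2ccccc2)=C1OCc1ccccc1`: > 100000 nM
compound 2 `O=C1O/C(=C\Cn2cnc3cncc(Br)c32)C(OCc2ccccc2)=C1OCc1ccccc1`: 46900 nM
compound 3 `O=C1NC(O)(CCn2cnc3ccnc(Cl)c32)C(OCc2ccccc2)=C1OCc1ccccc1`: > 100000 nM

In a functional assay on HepG2 cells (Homo sapiens) for antiproliferative activity, read by MTT assay, with a stated time of 72 h (a lower number here means a stronger inhibitor, a higher number a weaker inhibitor), compound 2 gives 46900 nM, the only number shown in the set. Compound 1 gives only a limit of the assay, > 100000 nM. Compound 3 likewise gives only a limit, > 100000 nM.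

Compound 4 `O=C1O/C(=C\Cn2cnc3c(Cl)c(F)nc(F)c32)C(OCc2ccccc2)=C1OCc1ccccc1` differs from compound 2 as follows: a group of 12 heavy atoms (6 carbon, 3 nitrogen, 2 fluorine, 1 chlorine; one five-membered aromatic ring with 2 hetero atoms, one six-membered aromatic ring with 1 hetero atom) in place of a group of 10 heavy atoms (6 carbon, 3 nitrogen, 1 bromine; one five-membered aromatic ring with 2 hetero atoms, one six-membered aromatic ring with 1 hetero atom), on a saturated chain carbon bound to a double-bonded chain carbon. For the measured compounds named here, the one measured step that bears on this is an at least 2.1-fold lower number from compound 1 to compound 2 (0.32 log units; beyond the scatter), which runs the opposite way and starts from the limit of > 100000 nM in this assay, at which 2 of the 3 values shown sit. The group entering compound 4 matches the group of compound 1 in atom count, so the change is expected to undo that step. Compound 4 is therefore expected to give a 2.1-fold higher number from compound 2 to compound 4 (0.33 log units; beyond the scatter), an estimated 100000 nM with a range from 40000 nM to 300000 nM, quite possibly reported only as a limit.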

Compound 4, half-maximal inhibitory concentration: > 100000 nM
Compound 4 ended at the assay's limit (the forecaster's own chance of this, stated with the estimate: 65%); the middle value lies on the limit itself.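

In this assay the group with 2 fluorine and 1 chlorine, in a second arrangement on the saturated chain carbon, gives an at least 2.1-fold higher number from compound 2 to compound 4 (0.32 log units; beyond the scatter), so neither arrangement of these atoms keeps the measurable value of compound 2. The step between the two limits cannot be read, which leaves the two arrangements unranked. The series now gathers at one ceiling: the limit of > 100000 nM in this assay, at which 3 of the 4 values shown sit.

Still open, from the compounds shown here alone, is whether an amine or a methyl group in place of the bromine of compound 2 gives a lower number. With a single measured value, the compounds shown give no trend among the groups at this place.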